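From naphthalen-1-yl to 4-methoxyphenyl on a shared core

This account rests on a few compounds, and the source may have more. Where it says the series, first, only, none or still open, it means among the compounds named here.

Compound 1 `COc1cc(/C=C/C(=O)/C=C/c2cccc3ccccc23)ccc1OCc1cn(CCOc2cc(=O)oc3ccccc23)nn1` gives 83%
Compound 2 `COc1ccccc1/C=C/C(=O)/C=C/c1ccc(OCc2cn(CCCOc3cc(=O)oc4ccccc34)nn2)c(OC)c1` gives 53%
Compound 3 `COc1ccc(/C=C/C(=O)/C=C/c2ccc(OCc3cn(CCCCOc4cc(=O)oc5ccccc45)nn3)c(OC)c2)cc1` gives 40%

In a functional assay on HCT-116 cells (Homo sapiens) for inhibition, read by sulforhodamine B assay, with a stated time of 48 h, tested at 50 uM (on this read-out lower numbers stand for less inhibition of growth and higher numbers for more inhibition of growth at the one concentration tested), compound 1 has the highest of the three numbers (83%). The gaps that separate it from the other two compounds lie beyond the scatter. Compound 4 `COc1ccc(/C=C/C(=O)/C=C/c2ccc(OCc3cn(CCOc4cc(=O)oc5ccccc45)nn3)c(OC)c2)cc1` is compound 1 with one change, 4-methoxyphenyl in place of naphthalen-1-yl on a double-bonded chain carbon bound to a double-bonded chain carbon. Within the data shown here, no measured pair shows this change alone, so the evidence for it is indirect. Compound 3 also carries 4-methoxyphenyl and gives 40% yet its chain differs from that of compound 4, which makes it only a rough guide. A fall beyond the scatter in this assay is therefore expected, with the size estimated as a number 28 percentage points lower from compound 1 to compound 4 (beyond the scatter) and known only loosely. The estimate for compound 4 is 55% (expected range 35% to 75%).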

Compound 4, percent growth inhibition at one concentration: 71%
Compound 4: the middle estimate sits 16 percentage points below what was measured; low and high end bracket the measured number.
By their numbers in this assay, from the lowest: compound 3; then compound 2; then compound 4; then compound 1.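

In this assay, among these compounds, putting 4-methoxyphenyl in place of naphthalen-1-yl on a double-bonded chain carbon bound to a double-bonded chain carbon gives a number 12 percentage points lower from compound 1 to compound 4 (beyond the scatter), and this is the first direct reading of that change with the rest of the molecule held constant. The place therefore accepts one six-membered aromatic ring instead of two at a modest cost, and compound 4 still gives 71% in this read-out. No measurement shown here explains the size of this step.

The compounds shown leave open how a plain phenyl ring, or a phenyl ring bearing an amine or a carboxylic acid, would behave at this place. They also leave open whether naphthalen-1-yl keeps its edge when a longer chain is present elsewhere on the shared core.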